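The source may report more compounds than this note shows. Statements on the series, on what has been measured and on what is new or still open speak of the compounds shown alone.

Cytotoxicity in a toxicity assay on MDCK cells (Canis lupus familiaris) for cytotoxicity, read by crystal violet staining, with a stated time of 48 h (a lower number here means that less compound is tolerated, a higher number that more compound is tolerated), is recorded for three compounds of the series, each as a limit of the assay rather than a number. Compound 1 `Cc1ccc2cc(C(C)N(Cc3ccc(F)cc3)Cc3ccc(C(C)C)cc3)c(=O)[nH]c2c1` gives a limit of > 33000 nM. Compound 2 `Cc1ccc2cc(CN(Cc3ccc(F)cc3)Cc3ccc(C(C)(C)C)cc3)c(=O)[nH]c2c1` likewise gives a limit of > 33000 nM. Compound 3 `CCCCOc1ccc(CN(Cc2ccc(C(C)(C)C)cc2)Cc2cc3cc(C)ccc3[nH]c2=O)cc1` gives a limit of > 5000 nM. Going by the values given here, compound 3 therefore stands only at a limit in this assay, and the two other values are limits as well, so no step between measured compounds can be stated; what the series shows is the limit of > 33000 nM in this assay, at which 2 of the 3 values shown sit, and (the limit of > 5000 nM in this assay, at which 1 of the 3 values shown sits). Compound 4 `Cc1ccc2[nH]c(=O)c(CN(Cc3ccc(C(C)(C)C)cc3)C(C)c3ccc(N(C)C)c(Cl)c3)cc2c1` is not yet measured. It differs from compound 3 in one place: 1-(3-chloro-4-(dimethylamino)phenyl)ethyl in place of 4-butoxybenzyl on an amine nitrogen. Among the compounds with values here, with no measured step, no shift beyond the usual scatter is expected in this assay from this change, and the expected step is a step that the limit leaves unreadable from compound 3 to compound 4. Compound 4 is estimated at 20000 nM, with a range from 5000 nM to 60000 nM. A limit rather than a number is the more likely report for compound 4, as for the three compounds already measured.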

Compound 4, half-maximal cytotoxic concentration: 9800 nM
For compound 4 the middle estimate is 2.0-fold (0.31 log units) above the measured one; measured number inside the range.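

In this assay, going by these compounds alone, the value of compound 3 is a limit, not a number, so no step to compound 4 can be read. The compounds shown leave open whether 1-(3-chloro-4-(dimethylamino)phenyl)ethyl in place of 4-butoxybenzyl shifts the tolerated concentration at all, and in which direction.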